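The compounds below may be only part of what the source reports. "The series", "measured", "known", "first", "only" and "open" are said of these compounds alone.

Measured so far:
compound 1 `CCCCc1ccccc1-c1n[nH]c(-c2ccccc2)n1`: in a functional assay on the whole organism (Cricetulus griseus) with Cricetinae gen. sp. as the target (on this read-out higher numbers stand for an effect only at larger amounts of compound and lower numbers for an effect already at smaller amounts), compound 1 gives 17 mg/kg
compound 2 `CCCCc1ccccc1-c1n[nH]c(-c2cccc(OC)c2)n1`: in this assay compound 2 gives 12 mg/kg
compound 3 `COc1ccc(-c2n[nH]c(-c3ccccc3)n2)c(C)c1`: for compound 3 the this assay result is a limit of the assay and not a number, > 10 mg/kg

From compound 1 to compound 2 the structural change is methoxy in place of hydrogen on an aromatic carbon, and the measured step is a 1.4-fold lower number from compound 1 to compound 2 (0.15 log units; within the scatter). The difference between the core of compound 1 and the core of compound 3 is not broken down here. Compound 4 `COc1cccc(-c2nc(-c3ccc(OC)cc3C)n[nH]2)c1` is not yet measured in this assay. Going by the values given here, it arises from compound 3 by methoxy in place of hydrogen on an aromatic carbon, the same change as the one from compound 1 to compound 2, at the same kind of place. The step from compound 3 to compound 4 in this assay is expected to be a step that the limit leaves unreadable from compound 3 to compound 4, which rests on the earlier step of a 1.4-fold lower number from compound 1 to compound 2 (0.15 log units; within the scatter) being within the scatter, and on compound 3 being known only by its limit (the limit of > 10 mg/kg in this assay, at which 1 of the 3 values shown sits). Compound 4 is therefore estimated at 15 mg/kg in this assay, with the expected range running from 6 mg/kg to 40 mg/kg.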

Compound 4, dose for half-maximal effect: 0.2 mg/kg
Estimate against measurement, compound 4: 75-fold (1.88 log units) above, outside the stated range (below it).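

In this assay, methoxy in place of hydrogen on an aromatic carbon gives an at least 50-fold lower number from compound 3 to compound 4 (1.69 log units; beyond the scatter), so the step seen on the core of compound 1 does not carry over to the core of compound 3: the same change on two cores in this assay, a 1.4-fold lower number (0.15 log units; within the scatter) from compound 1 to compound 2 and an at least 50-fold lower number (1.69 log units; beyond the scatter) from compound 3 to compound 4, at least 35-fold (1.54 log units) apart, beyond the scatter of two such steps Compound 3 stands at > 10 mg/kg, which is a limit of the assay and not a number, so this step has no exact size. The series shows that the effect of this change depends on the core in these two pairs, but it does not show which part of the difference between the cores goes with the gap, or how the change would behave on a third core.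

From the compounds shown here alone, it remains open whether a group other than methoxy, such as a hydroxyl or an amine, on the same aromatic carbon of the core of compound 3 would keep a number as low as that of compound 4, 0.2 mg/kg. Also open, going by these compounds, is whether a carboxylic acid at that place would behave alike on the core of compound 1 and the core of compound 3.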